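The source may report more compounds than this note shows. Statements on the series, on what has been measured and on what is new or still open speak of the compounds shown alone.

Working notes on the series. Three compounds share one core and differ only in the group on a saturated chain carbon bound to an oxygen on an aromatic ring. Compound 1 `COc1ccccc1COc1c(-c2ccccc2)oc2cc(O)cc(O)c2c1=O` gives 53000 nM in an ADME assay on Huh-5-2 cells (Homo sapiens) for cytotoxicity, read by WST assay, with a stated time of 3 days; a lower number here means that less compound is tolerated, a higher number that more compound is tolerated. Compound 2 `O=c1c(OCc2cccc(Cl)c2)c(-c2ccccc2)oc2cc(O)cc(O)c12` gives 46000 nM in this assay, and compound 3 `O=c1c(OCc2cccc([N+](=O)[O-])c2)c(-c2ccccc2)oc2cc(O)cc(O)c12` gives 31000 nM in this assay. For the measured compounds named here, compound 3 stands where the steps of a 1.7-fold lower number from compound 1 to compound 3 (0.23 log units; within the scatter) and a 1.5-fold lower number from compound 2 to compound 3 (0.17 log units; within the scatter) place it, and the step of a 1.2-fold lower number from compound 1 to compound 2 (0.06 log units; within the scatter) is of the same kind: none of the three exchanges at this position separates the compounds beyond the scatter, so no compound among the three can be set apart from the others.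

Compound 4 `N#Cc1ccc(COc2c(-c3ccccc3)oc3cc(O)cc(O)c3c2=O)cc1` has not been measured. The change from compound 3 is 4-cyanophenyl in place of 3-nitrophenyl on a saturated chain carbon bound to an oxygen on an aromatic ring. Going by the values given here, the steps that bear on it are the three above, each an exchange of the group at this same place, and each within the scatter. In this assay a step beyond the scatter is therefore not expected in either direction; the step of a 1.3-fold higher number from compound 3 to compound 4 (0.11 log units; within the scatter) is the estimate for this change. Compound 4 is expected at 40000 nM, with a range from 20000 nM to 80000 nM.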

Compound 4, half-maximal cytotoxic concentration: 48000 nM
Estimate against measurement, compound 4: 1.2-fold (0.08 log units) below, within the range that was stated.
By their numbers in this assay, from the lowest: compounds 3, 2, 4 and 1 (each within the scatter of the next).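

In this assay, the step to 4-cyanophenyl brings a nitrile and a triple bond to this position, and a 1.5-fold higher number from compound 3 to compound 4 (0.19 log units; within the scatter) shows that compound 3 is not set apart from this new group, a point that compounds 1 and 2 could address only for the groups they carry. For the compounds shown here, with a 1.0-fold higher number from compound 2 to compound 4 (0.02 log units; within the scatter) and a 1.1-fold lower number from compound 1 to compound 4 (0.04 log units; within the scatter) as well, all six exchanges among the four compounds now stay within the scatter, and no compound of the four goes against this, so 2-methoxyphenyl, 3-chlorophenyl, 3-nitrophenyl and 4-cyanophenyl cannot be told apart here. Nothing at hand accounts for how closely these groups agree at this position.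

From the compounds shown here alone, all four groups are substituted phenyl rings on the same saturated chain carbon, so it stays open whether the same agreement would hold for a group of another kind, such as an amine or a carboxylic acid on that ring, or for a longer chain in place of that single carbon. The shared core is also the same throughout, which leaves open whether the flat picture at this position would persist with any change made elsewhere on the core.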